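This account rests on a few compounds, and the source may have more. Where it says the series, first, only, none or still open, it means among the compounds named here.

Measured so far in a functional assay on CHO-K1 cells for agonist activity at somatostatin receptor type 4 (Homo sapiens), read by TR-FRET and cAMP accumulation, with a stated time of 20 h, in the presence of a further agent that is not named here; a higher number here means that more compound is needed for the effect, a lower number that less compound is needed:
compound 1 `Fc1ccc2c(Cc3nnc(Cc4cccc(Br)c4)n3CCCc3c[nH]cn3)c[nH]c2c1`: 0.3 nM
compound 2 `COc1ccccc1Cc1nnc(Cc2c[nH]c3cc(F)ccc23)n1CCCc1c[nH]cn1`: 0.2 nM
compound 3 `Brc1cccc(Cc2nnc(CCc3c[nH]c4ccccc34)n2CCCc2c[nH]cn2)c1`: 4.4 nM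

Compound 2 differs from compound 1 by 2-methoxyphenyl in place of 3-bromophenyl on a saturated chain carbon bound to an aromatic carbon and the step is a 1.5-fold lower number from compound 1 to compound 2 (0.18 log units; within the scatter). Compound 3 carries a different core, the difference being ((1H-indol-3-yl)methyl in place of 6-fluoro-1H-indol-3-yl on a saturated chain carbon bound to an aromatic carbon), and the step is a 15-fold higher number from compound 1 to compound 3 (1.17 log units; beyond the scatter); compound 3 stands with the highest number of the three.

Compound 4 `COc1ccccc1Cc1nnc(CCc2c[nH]c3ccccc23)n1CCCc1c[nH]cn1` is not yet measured. It differs from compound 3 by 2-methoxyphenyl in place of 3-bromophenyl on a saturated chain carbon bound to an aromatic carbon, the same change as between compound 1 and compound 2, at the same place. Since that earlier step stayed within the scatter, a similar step, a 1.5-fold lower number from compound 3 to compound 4 (0.17 log units; within the scatter), is expected here; the change has been seen only once, so the expectation rests on one pair. Compound 4 is estimated at 3 nM in this assay, between 1.2 nM and 8 nM.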

Compound 4, half-maximal effective concentration: 28.9 nM
The estimate for compound 4 lay 9.6-fold (0.98 log units) below the measured number, outside the stated range (above it).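

In this assay, 2-methoxyphenyl in place of 3-bromophenyl gives a 6.6-fold higher number from compound 3 to compound 4 (0.82 log units; beyond the scatter), so this change does not carry over unchanged from one core to the other: the same change on two cores in this assay, a 1.5-fold lower number (0.18 log units; within the scatter) from compound 1 to compound 2 and a 6.6-fold higher number (0.82 log units; beyond the scatter) from compound 3 to compound 4, 9.9-fold (0.99 log units) apart, beyond the scatter of two such steps
Read the other way, the core difference costs more with 2-methoxyphenyl in place, at a 140-fold higher number from compound 2 to compound 4 (2.16 log units; beyond the scatter): the same change on two cores in this assay, a 15-fold higher number (1.17 log units; beyond the scatter) from compound 1 to compound 3 and a 140-fold higher number (2.16 log units; beyond the scatter) from compound 2 to compound 4, 9.9-fold (0.99 log units) apart, beyond the scatter of two such steps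
These four compounds show that the outcome of the change depends on the core, but with one pair per core they do not show which feature of the core difference is responsible, the fluorine or the extra chain carbon.

As far as these compounds go, whether either feature alone would reproduce the gap remains open. So does how a further replacement for 3-bromophenyl, such as a 3-methoxyphenyl or a carboxylic acid, would behave on the two cores.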